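This account rests on a few compounds, and the source may have more. Where it says the series, first, only, none or still open, it means among the compounds named here.

In a functional assay on L1210 cells (Mus musculus) for inhibition (a lower number here means a stronger inhibitor, a higher number a weaker inhibitor), compound 1 (`C=C1[C@H](n2cnc3c(N)nc(N)nc32)O[C@H](CO)[C@H]1O`) gives 8200 nM, compound 2 (`C=C1[C@H](n2cnc3c(O)nc(N)nc32)O[C@H](CO)[C@H]1O`) gives 8500 nM and compound 3 (`C=C1[C@H](n2cnc3c(N)ncnc32)O[C@H](CO)[C@H]1O`) gives 65000 nM, the highest number of the three. Compound 4 (`C=C1[C@H](n2cnc3c(O)ncnc32)O[C@H](CO)[C@H]1O`) differs from compound 3 by one exchange, hydroxy in place of amino on an aromatic carbon. The same exchange has been measured once, as a 1.0-fold higher number from compound 1 to compound 2 (0.02 log units; within the scatter), and that step lies within the scatter. The larger step, a 7.9-fold higher number from compound 1 to compound 3 (0.90 log units; beyond the scatter), is hydrogen in place of amino, a different exchange, so it does not bear directly on this one. Going by the values given here, only one precedent exists, but no change beyond the scatter is expected in this assay. The expected step is a 1.1-fold higher number from compound 3 to compound 4 (0.03 log units; within the scatter). Compound 4 is estimated at 70000 nM, with an expected range of 28000 nM to 170000 nM.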

Compound 4, half-maximal inhibitory concentration: 60000 nM
Compound 4: middle estimate off by 1.2-fold (0.07 log units), on the high side, and the stated range covers the measured number.
By their numbers in this assay, from the lowest: compounds 1 and 2 (each within the scatter of the next); then compounds 4 and 3 (each within the scatter of the next).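

In this assay, hydroxy in place of amino on this aromatic carbon again makes no difference beyond the scatter, now on the core lacking the other amino group, a 1.1-fold lower number from compound 3 to compound 4 (0.03 log units; within the scatter), so the exchange holds on both cores: the same change on two cores in this assay, a 1.0-fold higher number (0.02 log units; within the scatter) from compound 1 to compound 2 and a 1.1-fold lower number (0.03 log units; within the scatter) from compound 3 to compound 4, 1.1-fold (0.05 log units) apart, within the scatter of two such steps. The loss of that other amino group also recurs with hydroxy at this position, a 7.1-fold higher number from compound 2 to compound 4 (0.85 log units; beyond the scatter), matching its size with amino there: the same change on two cores in this assay, a 7.9-fold higher number (0.90 log units; beyond the scatter) from compound 1 to compound 3 and a 7.1-fold higher number (0.85 log units; beyond the scatter) from compound 2 to compound 4, 1.1-fold (0.05 log units) apart, within the scatter of two such steps.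

From the compounds shown here alone, only amino and hydroxy stand at this position, so whether a methoxy group or a chlorine atom would behave alike stays open.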